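The source may report more compounds than this note shows. Statements on the series, on what has been measured and on what is new or still open speak of the compounds shown alone.

Working notes on the series. Going by the values given here, in a physicochemical assay for lipophilicity (on this read-out lower numbers stand for lower lipophilicity and higher numbers for higher lipophilicity), compound 1 (`CC(=O)O[C@H]1[C@@H](COC(=O)c2ccccc2)C[C@]2(OC(=O)/C=C/c3ccccc3)C(=O)/C(C)=C/[C@@H]3[C@H](CC[C@@]4(C)O[C@@H]4[C@@H]12)C3(C)C`) stands at 7.9 and holds the higher of the two numbers so far, while compound 2 (`C=C1[C@@H](OC(=O)C(C)CC)[C@@H](OC(C)=O)C(=O)C(C)(C)/C=C/[C@H](C)[C@H](OC(=O)c2ccccc2)[C@@]2(O)C[C@H](C)[C@H](OC(C)=O)[C@@H]2[C@H]1OC(C)=O`) gives 4.5 on the same scale. That gap lies beyond the usual scatter. Among the compounds with values here, no two measured compounds differ in one place only, so no measured step is available for sizing the next change.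

Compound 3 (`CC(=O)OC[C@H]1C[C@]2(OC(=O)/C=C/c3ccccc3)C(=O)/C(C)=C/[C@@H]3[C@H](CC[C@@]4(C)O[C@@H]4[C@H]2[C@H]1OC(C)=O)C3(C)C`) has not yet been measured. Going from compound 1 to compound 3, the change is methyl in place of phenyl on a carbonyl carbon, which reads as (benzoyloxy)methyl to acetoxymethyl (methyl in place of phenyl on a carbonyl carbon) with the rest of the core of compound 1 kept. A step towards lower numbers in this assay is expected, beyond the scatter, though this expectation rests on the structural change alone. The estimated step is a number 1.60 log units lower from compound 1 to compound 3 (beyond the scatter) with wide margins for that reason. In this assay compound 3 is estimated at 6.3 with an expected range from 5.6 to 7 once measured.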

Compound 3, partition coefficient: 6.2
Compound 3: middle estimate off by 0.10 log units, on the high side; low and high end bracket the measured number.
By their numbers in this assay, from the lowest: compound 2; then compound 3; then compound 1.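

The pair of compound 1 and compound 3 gives the series its first measured step at a single place: in this assay the exchange of (benzoyloxy)methyl for acetoxymethyl, methyl in place of phenyl on a carbonyl carbon, gives a number 1.70 log units lower from compound 1 to compound 3 (beyond the scatter) with the rest of the core of compound 1 kept. The group on this carbonyl carbon is thus shown to move the read-out by a large amount beyond the scatter, and the series now has a measured size for this one change, which the comparison of compound 1 with compound 2 could not supply. Nothing measured here accounts for the size of this step.

The compounds shown place only phenyl and methyl on this carbonyl carbon, so it stays open where a longer chain such as propyl, or an amine in the same place, would fall relative to compound 3 and compound 1. This single pair also leaves open whether the same exchange gives a step of similar size on any other core.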